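Amide nitrogen variation in a trimethoxyphenyl triazole series

This account rests on a few compounds, and the source may have more. Where it says the series, first, only, none or still open, it means among the compounds named here.

Read-out: a functional assay on the whole organism for inhibition, with Rattus norvegicus as the target, read by paw edema, with stated times of 30 min and 2 h, at a dose of 0.28 mmol/kg by the oral route; a lower number here means less inhibition, a higher number more inhibition at the dose given (going by the name of the read-out).

Measured so far:
compound 1 `COc1ccc(-n2nc(C(N)=O)nc2-c2cc(OC)c(OC)c(OC)c2)cc1`: 59%
compound 2 `CCNC(=O)c1nc(-c2cc(OC)c(OC)c(OC)c2)n(-c2ccc(OC)cc2)n1`: 68%
compound 3 `COc1ccc(-n2nc(C(=O)Nc3ccccc3OC)nc2-c2cc(OC)c(OC)c(OC)c2)cc1`: 57%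

Compound 2, carrying ethyl on the amide-type nitrogen, holds the highest of the three numbers. Its nearest neighbour is compound 1, the step of a number 9 percentage points higher from compound 1 to compound 2 (within the scatter); its furthest is compound 3, the step of a number 11 percentage points lower from compound 2 to compound 3 (beyond the scatter). Between compound 1 and compound 3 the step is a number 2 percentage points lower from compound 1 to compound 3 (within the scatter), so hydrogen and 2-methoxyphenyl on that nitrogen give numbers that cannot be told apart.

Compound 4 `COc1ccc(-n2nc(C(=O)Nc3ccc(C)cc3)nc2-c2cc(OC)c(OC)c(OC)c2)cc1` differs from compound 2 in one place: 4-methylphenyl in place of ethyl on an amide-type nitrogen. The step that bears on this most directly is the one from ethyl to 2-methoxyphenyl on the same nitrogen, a number 11 percentage points lower from compound 2 to compound 3 (beyond the scatter), a modest drop. The step to compound 4 also exchanges ethyl for an aryl group, so a drop of comparable size is the expectation, though no ring-substituted aryl other than 2-methoxyphenyl has been measured and the outcome could as well fall within the scatter. The estimated step is a number 10 percentage points lower from compound 2 to compound 4 (within the scatter). For compound 4 the expected value in this assay is 58%, with a range from 45% to 70%.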

Compound 4, a percentage reported as inhibition, in the whole organism at one dose (the size of the read-out at that dose, not a potency): 60%
The estimate for compound 4 lay 2 percentage points below the measured number; measured number inside the range.
By their numbers in this assay, from the lowest: compounds 3, 1, 4 and 2 (each within the scatter of the next, the first and the last beyond it).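

In this assay an aryl group on the amide-type nitrogen does not by itself set a compound apart from the ethyl amide: the 4-methylphenyl change gives a step within the scatter (a number 8 percentage points lower from compound 2 to compound 4 (within the scatter)), whereas the earlier 2-methoxyphenyl change gave one beyond it (a number 11 percentage points lower from compound 2 to compound 3 (beyond the scatter)). The two aryl groups cannot be told apart (a number 3 percentage points higher from compound 3 to compound 4 (within the scatter)), and 4-methylphenyl cannot be told apart from hydrogen on this nitrogen (a number 1 percentage points higher from compound 1 to compound 4 (within the scatter)). No measurement here offers an explanation for these numbers.

Still open, as far as these compounds go, is whether a longer chain such as butyl, or a chain ending in an amine or a carboxylic acid, on this nitrogen would move the number beyond the scatter of the ethyl amide. Unsubstituted phenyl would also show whether the ring substituents matter at all.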